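Swapping the Aryl Cap for Pyridin-4-yl in Compound 4

This account rests on a few compounds, and the source may have more. Where it says the series, first, only, none or still open, it means among the compounds named here.

Three close relatives share one core and differ only in the aromatic group hanging from the carbon that is double-bonded to nitrogen. Compound 1 `COc1ccc(/C=N/NC(=O)Nc2ccc(Oc3ccnc4cc(OCCCN5CCCCC5)c(OC)cc34)c(F)c2)cc1` gives 590 nM in a functional assay on HT-29 cells (Homo sapiens) for cytotoxicity, read by MTT assay, with a stated time of 72 h; on this read-out higher numbers stand for weaker inhibition and lower numbers for stronger inhibition. Compound 2 `COc1ccc(/C=N/NC(=O)Nc2ccc(Oc3ccnc4cc(OCCCN5CCCCC5)c(OC)cc34)c(F)c2)c(OC)c1` gives 1600 nM in this assay, and the step of a 2.7-fold higher number from compound 1 to compound 2 (0.43 log units; beyond the scatter) is a modest weakening. Compound 3 `COc1cc2c(Oc3ccc(NC(=O)N/N=C/c4ccc(N(C)C)cc4)cc3F)ccnc2cc1OCCCN1CCCCC1` gives 1000 nM in this assay; its number sits between those of compound 1 and compound 2, and the steps of a 1.7-fold higher number from compound 1 to compound 3 (0.23 log units; within the scatter) and a 1.6-fold lower number from compound 2 to compound 3 (0.20 log units; within the scatter) both lie within the scatter, so the three are hard to tell apart apart from the modest step to compound 2.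

Compound 4 `COc1cc2c(Oc3ccc(NC(=O)N/N=C/c4ccncc4)cc3F)ccnc2cc1OCCCN1CCCCC1` has not yet been measured in this assay. It differs from compound 3 in one place: pyridin-4-yl in place of 4-(dimethylamino)phenyl on a carbon with a double bond to nitrogen. Among the compounds with values here, none of the measured steps swaps the whole aromatic ring for a ring containing a nitrogen atom, so they give only weak guidance; the two steps touching compound 3 were within the scatter and the one beyond it was modest. Compound 4 is therefore expected to stay near compound 3, with a step of a 1.5-fold higher number from compound 3 to compound 4 (0.18 log units; within the scatter) that need not exceed the scatter. The estimate for compound 4 in this assay is 1500 nM, within a range from 500 nM to 5000 nM.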

Compound 4, half-maximal inhibitory concentration: 940 nM
For compound 4 the middle estimate is 1.6-fold (0.20 log units) above the measured one, within the range that was stated.
By their numbers in this assay, from the lowest: compounds 1, 4, 3 and 2 (each within the scatter of the next, the first and the last beyond it).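

With a 1.1-fold lower number from compound 3 to compound 4 (0.03 log units; within the scatter) in this assay, the position on the carbon with a double bond to nitrogen takes a ring holding a hetero atom, and pyridin-4-yl, with 6 heavy atoms, cannot be told apart from 4-(dimethylamino)phenyl, with 9. The comparisons with the other two aromatic groups read the same way: both a 1.7-fold lower number from compound 2 to compound 4 (0.23 log units; within the scatter) and a 1.6-fold higher number from compound 1 to compound 4 (0.20 log units; within the scatter) stay inside the usual scatter, so compound 4 cannot be separated from any of the three earlier compounds, even though compound 1 and compound 2 can be separated from each other. No measurement here accounts for how little the number moves across these different rings.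

All four groups at this position are six-membered aromatic rings, so the compounds shown leave open what a non-aromatic group such as cyclohexyl would do there. Also open, on these data alone, is how the number would respond to a ring carrying a carboxylic acid or a primary amine, groups that none of these aromatic rings bears.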